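A few compounds are considered here, and "the series" means these few. Any claim that something is new, unique, unknown or untested is made for them only; others in the source may bear on it.

Compound 2 `O=C(O)Cc1sc(C(c2ccc(F)cc2)c2ccc(F)cc2)nc1-c1ccccc1` gives 240 nM in an in vitro functional assay on HEK285-7 cells for antagonist activity at prostaglandin D2 receptor 2 (Homo sapiens), read by BRET and beta-arrestin recruitment; on this read-out higher numbers stand for weaker inhibition and lower numbers for stronger inhibition. Among the three compounds measured, compound 2 stands highest. Compound 3 `O=C(O)Cc1sc(C(c2ccccc2)c2ccccc2)nc1-c1ccc(F)c(F)c1` gives 43 nM in this assay, a number beyond the scatter below that of compound 2, and compound 1 `O=C(O)Cc1sc(C(c2ccccc2)c2ccc(F)cc2)nc1-c1ccc(Cl)cc1` gives 36 nM in this assay, further below still. For the measured compounds named here, the three compounds differ in more than one place, so no single step between them is counted.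

Compound 4 `O=C(O)Cc1sc(C(c2ccc(F)cc2)c2ccc(F)cc2)nc1-c1ccncc1` has not been measured. It differs from compound 2 in one place: pyridin-4-yl in place of phenyl on an aromatic carbon. Going by the values given here, no measured pair shows the effect of this change, so the expectation for compound 4 rests only on compound 2 itself.

The author expects the step of a 1.7-fold higher number from compound 2 to compound 4 (0.22 log units; within the scatter) to be small, within the scatter or slightly upward, as nothing in the measured compounds speaks to this change. Compound 4 is therefore estimated to give 400 nM in this assay, in a range from 120 nM to 1300 nM.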

Compound 4, half-maximal inhibitory concentration: 40 nM
Compound 4: middle estimate off by 10-fold (1.00 log units), on the high side, and the stated range ends above it.
By their numbers in this assay, from the lowest: compounds 1, 4 and 3 (each within the scatter of the next); then compound 2.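

For the compounds shown here, exchanging phenyl for pyridin-4-yl on this aromatic carbon, next to the ring nitrogen, gives the first single change that can be read: in this assay it brings a 6.0-fold lower number from compound 2 to compound 4 (0.78 log units; beyond the scatter). The position therefore responds to the identity of its aromatic ring, as one ring carbon replaced by nitrogen, with the rest of the compound unchanged, moves the number beyond the scatter and towards stronger inhibition. Nothing in the available data accounts for this shift.

On these data alone, it remains open whether a pyridin-3-yl, pyridin-2-yl or pyrimidin-5-yl group at this carbon would give a step of similar size, which would show how much depends on where the ring nitrogen stands. As far as these compounds go, it is also open whether pyridin-4-yl would bring a similar step on the cores of compound 1 and compound 3.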